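The source may report more compounds than this note shows. Statements on the series, on what has been measured and on what is new or still open speak of the compounds shown alone.

In a functional assay on RAW264.7 cells (Mus musculus) for inhibition (on this read-out higher numbers stand for weaker inhibition and lower numbers for stronger inhibition), compound 1 (`CCOC(=O)C1=CCCCC1S(=O)(=O)Nc1ccccc1Cl`) gives 12 nM, compound 2 (`CCOC(=O)C1=CCCCC1S(=O)(=O)Nc1ccc(F)cc1F`) gives 16 nM and compound 3 (`COC(=O)C1=CCCCC1S(=O)(=O)Nc1ccc(F)cc1F`) gives 57 nM, the highest number of the three. Compound 4 (`CC(C)OC(=O)C1=CCCCC1S(=O)(=O)Nc1ccc(F)cc1F`) differs from compound 3 at the ester: isopropyl in place of methyl on an oxygen next to a carbonyl group. Within the data shown here, the only measured step on this chain is a 3.6-fold higher number from compound 2 to compound 3 (0.55 log units; beyond the scatter), a modest one that removes a methyl from the chain. Compound 4 instead enlarges the chain, so a lower number is expected in this assay, though no branched chain has been measured. The expected size is an estimated 2.6-fold lower number from compound 3 to compound 4 (0.41 log units; beyond the scatter). For compound 4 the estimated value is 22 nM, within a range of 7 nM to 70 nM.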

Compound 4, half-maximal inhibitory concentration: 110 nM
Compound 4: middle estimate off by 5.0-fold (0.70 log units), on the low side; measured number outside the range, above it.
By their numbers in this assay, from the lowest: compounds 1 and 2 (each within the scatter of the next); then compounds 3 and 4 (each within the scatter of the next).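

Isopropyl in place of methyl on the oxygen next to the carbonyl group gives a 1.9-fold higher number from compound 3 to compound 4 (0.29 log units; within the scatter), so these two chains cannot be told apart here. The larger chain does not restore the number of the ethyl ester, with a 6.9-fold higher number from compound 2 to compound 4 (0.84 log units; beyond the scatter), so among these three esters, size does not track the read-out in one direction, and compound 2 gives the lowest number. Nothing available explains this behaviour at the ester.

As far as these compounds go, how a straight propyl chain, a tert-butyl group or the free carboxylic acid would read at this oxygen remains open. So does whether the ethyl ester's advantage holds with other groups on the aniline ring.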